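The compounds below may be only part of what the source reports. "The series", "measured", "known", "first", "only" and "open" are said of these compounds alone.

Series notes on the nitroimidazole-oxazine ethers in a physicochemical assay for solubility, read by HPLC, with a stated time of 4 h, at pH 7; a higher number here means a more soluble compound, a lower number a less soluble compound. Three members carry a number or a limit so far. The urea compound 1 `CCOc1ccc(NC(=O)Nc2ccc(OC[C@@]3(C)Cn4cc([N+](=O)[O-])nc4O3)cc2)cc1` gives 6.66 ug/mL in this assay. The piperidine sulfonamide compound 3 `C[C@]1(COc2ccc(S(=O)(=O)N3CCCCC3)cc2)Cn2cc([N+](=O)[O-])nc2O1` gives 13.3 ug/mL in this assay. For the piperazine sulfonamide compound 2 `C[C@]1(COc2ccc(N3CCN(S(=O)(=O)c4ccc(C(F)(F)F)cc4)CC3)cc2)Cn2cc([N+](=O)[O-])nc2O1` this assay returns only a limit, < 1 ug/mL, so its position among the three is known only as one of the values at the limit of < 1 ug/mL in this assay, at which 1 of the 3 values shown sits. The next member, compound 4 `C[C@]1(COc2ccc(N3CCN(S(=O)(=O)c4ccc(F)cc4)CC3)cc2)Cn2cc([N+](=O)[O-])nc2O1`, differs from compound 2 in one place: fluoro in place of trifluoromethyl on an aromatic carbon. Among the compounds with values here, no measured pair in the set shares this change, so its effect is untested here. In this assay the step from the limit is expected to be an at least 3.0-fold higher number from compound 2 to compound 4 (0.47 log units; beyond the scatter), and compound 4 is estimated at 3 ug/mL, with a range of 0.8 ug/mL to 12 ug/mL.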

Compound 4, solubility: 8.33 ug/mL
The estimate for compound 4 lay 2.8-fold (0.44 log units) below the measured number; low and high end bracket the measured number.
By their numbers in this assay, from the lowest: compounds 1, 4 and 3 (each within the scatter of the next). At a limit, below all of these: compound 2.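

In this assay, within the data shown here, fluoro in place of trifluoromethyl on the aromatic carbon gives an at least 8.3-fold higher number from compound 2 to compound 4 (0.92 log units; beyond the scatter) and is the first single-place change that can be read. On these data alone, the true size of the step stays open-ended, as compound 2 carries only a limit: the limit of < 1 ug/mL in this assay, at which 1 of the 4 values shown sits. The read-out therefore responds to the group at this position, and compound 4 no longer sits at a limit.

This single pair cannot show whether the step carries over to other members. As far as these compounds go, how an amine, a carboxylic acid or a nitrile on this aromatic carbon would read in this assay remains open.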